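The source may hold more compounds than are shown below. What is called first, only, known or untested is meant among the compounds shown, and "the series" means these compounds.

Measured compounds:
- compound 1, `Nc1scc(CN2CCN(c3cccc4ccccc34)CC2)c1C(=O)c1ccc(Cl)cc1`: 0%
- compound 2, `Nc1scc(CN2CCN(c3ccc(F)c(Cl)c3)CC2)c1C(=O)c1ccc(Cl)cc1`: 0%

In an assay on CHO cells for displacement of a labelled ligand from adenosine receptor A3 (Homo sapiens), read by scintillation counting, with a stated time of 120 min, tested at 10 uM (a lower number here means less inhibition, a higher number more inhibition at the concentration tested (going by the name of the read-out)), compound 1 gives 0%. Compound 2 gives 0% in this assay. Among the measured compounds shown here, the only measured step, no change at the digits printed from compound 1 to compound 2 (within the scatter), leaves the read-out where it was. Compound 2 therefore stands level with compound 1, and neither compound shows any displacement at the concentration tested.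

Compound 3, `Nc1scc(CN2CCN(c3cc(Cl)ccc3Cl)CC2)c1C(=O)c1ccc(Cl)cc1`, has not been measured. It differs from compound 2 in one place: 2,5-dichlorophenyl in place of 3-chloro-4-fluorophenyl on an amine nitrogen in a ring

For the measured compounds named here, the single measured step bears directly on this change, since it also exchanged the group on the amine nitrogen in a ring while the rest of the shared core stayed the same, and it produced no change within the scatter. Going by the values given here, nothing among the measured compounds points to a gain or a loss for this assay from yet another exchange at that position. Compound 3 is therefore expected to show a step of no change at the digits printed from compound 2 to compound 3 (within the scatter) in this assay, none beyond the scatter. For compound 3 the estimate in this assay is 0%, in the range -8% to 10%.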

Compound 3, a percentage reported as inhibition, at one concentration (the size of the read-out at that concentration, not a potency): 1%
For compound 3 the middle estimate is 1 percentage points below the measured one; low and high end bracket the measured number.
By their numbers in this assay, from the lowest: compounds 1, 2 and 3 (each within the scatter of the next).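

With 2,5-dichlorophenyl in place of 3-chloro-4-fluorophenyl on an amine nitrogen in a ring, this assay records a number 1 percentage points higher from compound 2 to compound 3 (within the scatter), and with the same group in place of naphthalen-1-yl it records a number 1 percentage points higher from compound 1 to compound 3 (within the scatter). A third group at this position, this one carrying two chlorine atoms where compound 2 has one chlorine and one fluorine, therefore leaves the read-out level with the first two, and all three compounds stand within the scatter of one another. No separate measurement is available that could explain why these groups read alike.

All three groups on this nitrogen have a six-membered aromatic ring of carbon only, so the compounds shown do not tell whether a pyridine ring, a carboxylic acid or a short alkyl chain in that place would give any measurable inhibition at the concentration tested. They also leave open whether any change elsewhere on the shared core, such as an amide in place of the free amine, would shift the read-out from where these three compounds stand.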